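A few compounds are considered here, and "the series" means these few. Any claim that something is new, unique, unknown or untested is made for them only; others in the source may bear on it.

Compound 1 `CCOC(=O)C(COC(=O)c1ccccc1OC(C)=O)c1ccc(F)cc1` and compound 2 `CCOC(=O)C(COC(=O)c1ccccc1)c1ccc(C(F)(F)F)cc1` have both been tested in a functional assay on A2780 cells (Homo sapiens) for cytotoxicity, read by MTT assay, with a stated time of 72 h; a lower number here means a stronger inhibitor, a higher number a weaker inhibitor. Compound 1 gives > 0.01 ug/mL, which is a limit of the assay and not a number. Compound 2 gives > 0.01 ug/mL, which is also a limit, so compound 2 has no exact place on the scale. The evidence so far is therefore (the limit of > 0.01 ug/mL in this assay, at which 2 of the 2 values shown sit).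

Compound 3 `CCOC(=O)C(COC(=O)c1ccccc1OC(C)=O)c1ccc(C(F)(F)F)cc1` is compound 2 with a single change, phenyl to 2-acetoxyphenyl: acetoxy in place of hydrogen on an aromatic carbon. This puts acetoxy in place of hydrogen on an aromatic carbon, ortho to a large group. Going by the values given here, no measured step shows what this change does, so no shift beyond the usual scatter is expected in either direction. The expected change is a step that the limit leaves unreadable from compound 2 to compound 3. In this assay, the estimate for compound 3 is 0.02 ug/mL, with an expected range from 0.006 ug/mL to 0.1 ug/mL.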

Compound 3, half-maximal inhibitory concentration: > 0.01 ug/mL
Compound 3 was reported as a limit; the forecaster's own chance of this, stated with the estimate: 70%; the middle value is on the limit's open side.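

Compound 3, like compound 1 and compound 2, is reported only as a limit, so no step from compound 1 or compound 2 to compound 3 can be read: the limit of > 0.01 ug/mL in this assay, at which 3 of the 3 values shown sit.

The compounds shown leave open how strong each one really is, and whether acetoxy in place of hydrogen, or trifluoromethyl in place of fluoro, changes that at all.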